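Series notes: ring swap from compound 3 to compound 4

The compounds below may be only part of what the source reports. "The series", "measured", "known", "first", "only" and "open" are said of these compounds alone.

Three compounds built on the shared core have numbers in a functional assay on CHO-K1 cells for antagonist activity at transient receptor potential cation channel subfamily V member 1 (Homo sapiens), read by FLIPR; on this read-out higher numbers stand for weaker inhibition and lower numbers for stronger inhibition. Compound 1 `CC(C(=O)NCc1ccc(C(F)(F)F)nc1N1CCC(c2ccccc2)CC1)c1ccc(NS(C)(=O)=O)c(F)c1` gives 0.6 nM and compound 2 `CC(C(=O)NCc1ccc(C(F)(F)F)nc1N1CCC(C(F)(F)F)CC1)c1ccc(NS(C)(=O)=O)c(F)c1` gives 0.6 nM; no change at the digits printed from compound 1 to compound 2 (within the scatter). Compound 3 `CCCCOC1CCN(c2nc(C(F)(F)F)ccc2CNC(=O)C(C)c2ccc(NS(C)(=O)=O)c(F)c2)CC1` gives 3.5 nM, the highest of the three numbers: a 5.8-fold higher number from compound 1 to compound 3 (0.77 log units; beyond the scatter) and a 5.8-fold higher number from compound 2 to compound 3 (0.77 log units; beyond the scatter).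

Compound 4 `CC(C(=O)NCc1ccc(C(F)(F)F)nc1N1CCCCCCC1)c1ccc(NS(C)(=O)=O)c(F)c1` is not yet measured. Relative to compound 3 the change is a group of 8 heavy atoms (7 carbon, 1 nitrogen; one eight-membered non-aromatic ring with 1 hetero atom) in place of a group of 11 heavy atoms (9 carbon, 1 nitrogen, 1 oxygen; one six-membered non-aromatic ring with 1 hetero atom), on an aromatic carbon. Among the compounds with values here, no measured step covers this change directly: the steps from compound 1 and compound 2 to compound 3 exchange only the group on a saturated ring carbon, whereas compound 4 drops the six-membered ring together with its butoxy group and enters an eight-membered ring carrying no substituent. Those steps do show that the group on the saturated ring carbon shifts the number modestly, with the butoxy group of compound 3 giving the weakest inhibition of the three. Within the data shown here, removing that group might move the number back towards compound 1 and compound 2, but the ring enlargement has no precedent in this set, so the expectation is uncertain and leans towards a small gain at most. Compound 4 is expected to give 2.5 nM (between 0.6 nM and 10 nM), so the step of a 1.4-fold lower number from compound 3 to compound 4 (0.15 log units; within the scatter) is expected to be modest at most.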

Compound 4, inhibition constant: 0.7 nM
The estimate for compound 4 lay 3.6-fold (0.55 log units) above the measured number, and the stated range covers the measured number.
By their numbers in this assay, from the lowest: compounds 1, 2 and 4 (each within the scatter of the next); then compound 3.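

The eight-membered ring with no substituent, on the aromatic carbon next to the ring nitrogen, gives stronger inhibition than the butoxy-bearing six-membered ring in this assay (a 5.0-fold lower number from compound 3 to compound 4 (0.70 log units; beyond the scatter)), so among the compounds shown neither a six-membered ring nor a substituent on a saturated ring carbon is required for a low number at this position. Compound 4 also stands level with the phenyl and trifluoromethyl compounds (a 1.2-fold higher number from compound 1 to compound 4 (0.07 log units; within the scatter); a 1.2-fold higher number from compound 2 to compound 4 (0.07 log units; within the scatter)), which leaves compound 3 as the only one of the four apart from the others and shows that this place tolerates a change of ring size as well as a change of substituent. No measurement is available that accounts for the position of compound 3 or for the level numbers of the other three.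

The step to compound 4 changes ring size and removes the butoxy group together, so an unsubstituted six-membered ring or seven-membered ring would be needed to read these two changes apart. Also open, going by these compounds, is how a carboxylic acid, a primary amine or a methoxy group on a saturated ring carbon would read in this assay.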